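Ring Replacement and Half-Life in Buffer

The source may report more compounds than this note shows. Statements on the series, on what has been measured and on what is new or still open speak of the compounds shown alone.

Measured compounds:
Compound 1, `CN(C[C@@H]1[C@H](NC(=O)/C(=N\OC(C)(C)C(=O)O)c2csc(N)n2)C(=O)N1S(=O)(=O)O)C(=O)CN`, gives 212 h in a physicochemical assay for metabolic stability, read by HPLC and mass spectrometry, in phosphate buffer, at 37 degrees C, at pH 7.4; on this read-out higher numbers stand for a longer-lived compound and lower numbers for a shorter-lived compound.
Compound 2, `CC(C)(O/N=C(\C(=O)N[C@@H]1C(=O)N(S(=O)(=O)O)[C@@H]1CN1CCC1=O)c1csc(N)n1)C(=O)O`, gives > 1000 h, which is a limit of this assay rather than a number.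
Compound 3, `CC(C)(O/N=C(\C(=O)N[C@@H]1C(=O)N(S(=O)(=O)O)[C@@H]1CN1CCNC1=O)c1csc(N)n1)C(=O)O`, gives > 1000 h, likewise a limit.

Within the data shown here, compound 1 therefore holds the only outright number; the rest of the picture is the limit of > 1000 h in this assay, at which 2 of the 3 values shown sit.

Compound 4, `CC(C)(O/N=C(\C(=O)N[C@@H]1C(=O)N(S(=O)(=O)O)[C@@H]1CN1C[C@H](CN)OC1=O)c1csc(N)n1)C(=O)O`, differs from compound 1 in one place: 5-(aminomethyl)-2-oxo-1,3-oxazolidin-3-yl in place of ((aminomethyl)carbonyl)(methyl)amino on a saturated chain carbon bound to a saturated ring carbon. Among the measured compounds shown here, two measured steps bear on this kind of change, in which the open-chain group on that carbon gives way to a small ring bearing a carbonyl. One is an at least 4.7-fold higher number from compound 1 to compound 2 (0.67 log units; beyond the scatter); the other is an at least 4.7-fold higher number from compound 1 to compound 3 (0.67 log units; beyond the scatter). The step between the two ring compounds, a step that the two limits leave unreadable from compound 2 to compound 3, adds nothing readable.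

A rise in this assay is thus expected for compound 4, probably reaching the limit again. Compound 4 is expected to give about 1000 h, in a range from 350 h to 3000 h. That expectation means a step of a 4.7-fold higher number from compound 1 to compound 4 (0.67 log units; beyond the scatter).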

Compound 4, half-life: > 37 h
Compound 4 gave a limit, no number; the forecaster's own chance of this, stated with the estimate: 60%; the middle value is on the limit's open side.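

In this assay compound 4 gives > 37 h, which is a limit and not a number. Its steps from compound 1, compound 2 and compound 3 therefore cannot be read. The compounds shown leave open how long compound 4 actually lasts, and whether it outlasts compound 1 at all.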